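Ester in place of piperazine amide on the naphthyl series

The source may report more compounds than this note shows. Statements on the series, on what has been measured and on what is new or still open speak of the compounds shown alone.

compound 1 `CN1CCN(C(=O)/C=C/c2ccncc2-c2ccc3ccccc3c2)CC1`: 43.6 nM
compound 2 `O=C(/C=C/c1ccncc1-c1ccc2[nH]ccc2c1)N1CCOCC1`: 190 nM
compound 3 `CN1CCN(C(=O)/C=C/c2ccncc2-c2ccc(F)cc2)CC1`: 1210 nM

All three numbers come from an assay on a protein complex for inhibition of CDK8/Cyclin C (Homo sapiens), with a stated time of 1 h; on this read-out lower numbers stand for stronger inhibition and higher numbers for weaker inhibition. Compound 1 stands lowest of the three; compound 2 sits above it by a margin beyond the scatter, and compound 3 further still, also beyond the scatter. Compound 2 and compound 3 each differ from compound 1 in more than one place, so their values show only the spread of the series, not the weight of any single change.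

Compound 4 `COC(=O)/C=C/c1ccncc1-c1ccc2ccccc2c1` has not yet been measured in this assay. It differs from compound 1 in one place: methoxy in place of 4-methylpiperazin-1-yl on a carbonyl carbon. For the measured compounds named here, no step between measured compounds that differ in one place is available, so the size of this step cannot be read off from the series and has to be expected. The expectation is a step toward weaker inhibition that goes beyond the scatter, a 6.9-fold higher number from compound 1 to compound 4 (0.84 log units; beyond the scatter). For compound 4 the estimated value in this assay is 300 nM, with a range from 80 nM to 1500 nM.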

Compound 4, half-maximal inhibitory concentration: 40.6 nM
Estimate against measurement, compound 4: 7.4-fold (0.87 log units) above; measured number outside the range, below it.
By their numbers in this assay, from the lowest: compounds 4 and 1 (each within the scatter of the next); then compound 2; then compound 3.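

For the compounds shown here, exchanging 4-methylpiperazin-1-yl for methoxy on the carbonyl carbon gives, in this assay, a 1.1-fold lower number from compound 1 to compound 4 (0.03 log units; within the scatter), the only single-place reading so far. On the core of compound 1, this position therefore accepts the loss of the six-membered ring and its 7 heavy atoms, with methoxy's 2 heavy atoms in their place, without a change beyond the scatter, so the ring is not required for a number at this level. No supporting data are available to explain why the two groups read alike.

From the compounds shown here alone, whether the same exchange reads alike on the cores of compound 2 and compound 3 stays open. Also open, going by these compounds, is how this position reads with a carboxylic acid, a simple primary amide or a longer chain such as ethoxy.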